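The source may hold more compounds than are shown below. What is called first, only, known or untested is meant among the compounds shown, and "the series" means these compounds.

Measured in an assay on membranes from brain for displacement of a labelled ligand from Sigma non-opioid intracellular receptor 1 (Cavia porcellus), read by scintillation counting, with a stated time of 1 h; on this read-out higher numbers stand for weaker inhibition and lower numbers for stronger inhibition:
compound 1 `Cn1nc(CN2CCCCC2)nc1-c1ccc(C(C)(C)C)cc1` gives 3.7 nM
compound 2 `CN(Cc1nc(-c2ccc(C(C)(C)C)cc2)n(C)n1)CC1CC1` gives 0.61 nM

Among the compounds with values here, compound 1 holds the highest number of the two; the only measured step from it is a 6.1-fold lower number from compound 1 to compound 2 (0.78 log units; beyond the scatter). Compound 3 `CN1CCN(Cc2nc(-c3ccc(C(C)(C)C)cc3)n(C)n2)CC1` is not yet measured; it differs from compound 1 by 4-methylpiperazin-1-yl in place of piperidin-1-yl on a saturated chain carbon bound to an aromatic carbon. Within the data shown here, no measured step exchanges one ring amine for another, so the step from compound 1 to compound 2 bears only loosely on it. For compound 3 a step of about a 1.6-fold higher number from compound 1 to compound 3 (0.21 log units; within the scatter) in this assay is expected, within the scatter. Compound 3 is estimated at 6 nM, range 1.5 nM to 25 nM.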

Compound 3, inhibition constant: 131 nM
For compound 3 the middle estimate is 22-fold (1.34 log units) below the measured one; measured number outside the range, above it.
By their numbers in this assay, from the lowest: compound 2; then compound 1; then compound 3.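

In this assay, the group on the saturated chain carbon bound to an aromatic carbon can move the number far upward, not only down: 4-methylpiperazin-1-yl in place of piperidin-1-yl gives a 35-fold higher number from compound 1 to compound 3 (1.55 log units; beyond the scatter). The same group in place of (cyclopropylmethyl)(methyl)amino gives a 210-fold higher number from compound 2 to compound 3 (2.33 log units; beyond the scatter). Nothing at hand explains this loss.

As far as these compounds go, whether it follows the second ring nitrogen or its methyl stays open. Piperazin-1-yl and morpholin-4-yl at this place would separate those two readings.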